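Swapping the amine substituents on a tricyclic corticotropin-releasing factor ligand

The source may hold more compounds than are shown below. What is called first, only, known or untested is meant among the compounds shown, and "the series" means these compounds.

Of the compounds shown here, three that share a core have been tested in an assay on cells for displacement of a labelled ligand from corticotropin-releasing factor receptor 1 (Homo sapiens), with a stated time of 100 min; on this read-out higher numbers stand for weaker inhibition and lower numbers for stronger inhibition. Compound 1 `CCCN(CC1CC1)C(=O)c1c(C)nc2n(-c3c(C)cc(C)cc3C)c(Cl)cn12`, which carries an amide, gives 61 nM. Compound 2 `C=CCN(CC=C)Cc1c(C(F)(F)F)nc2n(-c3c(C)cc(C)cc3C)c(Cl)cn12`, in which the amide is replaced by a diallylamino group on a saturated chain carbon, gives 13 nM. Compound 3 `CCCN(Cc1ccc(F)cc1)Cc1c(C(F)(F)F)nc2n(-c3c(C)cc(C)cc3C)c(Cl)cn12`, with a propyl group and a 4-fluorobenzyl group on that nitrogen, gives 350 nM. Compound 2 therefore shows the strongest inhibition of the three, with compound 1 and compound 3 both clearly weaker.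

Compound 4 `Cc1cc(C)c(-n2c(Cl)cn3c(CN(C)Cc4ccco4)c(C(F)(F)F)nc23)c(C)c1` has not yet been measured. It differs from compound 2 in one place: ((furan-2-yl)methyl)(methyl)amino in place of diallylamino on a saturated chain carbon bound to an aromatic carbon. One of the two branches on the nitrogen becomes a single methyl group, while the other becomes a five-membered aromatic ring joined through a saturated carbon.

Among the measured compounds shown here, no measured pair isolates this exact change. Compound 3 indicates that a bulky aromatic arm on the nitrogen can weaken binding considerably, but compound 4 keeps the other arm small. A modest loss relative to compound 2 is therefore expected, and the expected step from compound 2 to compound 4 is a 3.8-fold higher number from compound 2 to compound 4 (0.59 log units; beyond the scatter). Compound 4 is estimated to give 50 nM in this assay, with a plausible range from 12 nM to 250 nM.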

Compound 4, inhibition constant: 180 nM
Estimate against measurement, compound 4: 3.6-fold (0.56 log units) below; low and high end bracket the measured number.
By their numbers in this assay, from the lowest: compound 2; then compound 1; then compounds 4 and 3 (each within the scatter of the next).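

In this assay, the amine on this saturated chain carbon cannot be swapped freely: replacing diallylamino with ((furan-2-yl)methyl)(methyl)amino gives a 14-fold higher number from compound 2 to compound 4 (1.14 log units; beyond the scatter) even though the rest of the molecule stays the same. A single methyl group on one branch is therefore not enough to keep the stronger inhibition of compound 2, and compound 4 at 180 nM and compound 3 at 350 nM lie within the usual scatter of each other despite carrying different amines. The data shown offer no measured explanation for this loss.

Both branches on the nitrogen change together in this step, so the compounds shown cannot say whether the loss follows from removing an allyl group in favour of the methyl group or in favour of the (furan-2-yl)methyl group. An amine carrying one allyl group and one methyl group, or one allyl group and one (furan-2-yl)methyl group, would change a single branch at a time and could separate these two contributions.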